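Replacing 2-carboxypropyl by 2-carbamoylcyclopropyl in the series

The source may report more compounds than this note shows. Statements on the series, on what has been measured and on what is new or still open speak of the compounds shown alone.

Compound 1 `Cc1nc(-c2ccc(C(F)(F)F)cc2)sc1CNc1ccc(C(=O)O)cc1`: in a functional assay on CHO cells for agonist activity at Free fatty acid receptor 1 (Homo sapiens) (on this read-out lower numbers stand for an effect already at smaller amounts and higher numbers for an effect only at larger amounts of compound), compound 1 gives only a limit, < 10000 nM.
Compound 2 `CC(Cc1ccc(NCc2cccc(Oc3ccccc3)c2)cc1)C(=O)O`: compound 2 gives 100 nM.
Compound 3 `Cc1nc(-c2ccc(C(F)(F)F)cc2)sc1CNc1ccc(CC(C)C(=O)O)cc1`: compound 3 gives 355 nM.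

Compound 3 holds the higher of the two read numbers, and its gap to compound 2 lies beyond the scatter. The step from compound 1 to compound 3, a step that the limit leaves unreadable from compound 1 to compound 3, cannot be sized due to the limit of < 10000 nM in this assay, at which 1 of the 3 values shown sits.

Compound 4 `Cc1nc(-c2ccc(C(F)(F)F)cc2)sc1CNc1ccc([C@H]2C[C@@H]2C(N)=O)cc1` differs from compound 3 by 2-carbamoylcyclopropyl in place of 2-carboxypropyl on an aromatic carbon. Within the data shown here, no measured step covers this change, and the single step seen is unreadable. Compound 4 is therefore expected near 2500 nM, with a range of 400 nM to 15000 nM. The expected step of a 7.0-fold higher number from compound 3 to compound 4 (0.85 log units; beyond the scatter) is towards larger amounts, with a real chance that only a limit is reported.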

Compound 4, half-maximal effective concentration: 4.47 nM
Beside the measured number, compound 4's estimate is 560-fold (2.75 log units) above it; the whole stated range lies above it.
By their numbers in this assay, from the lowest: compound 4; then compound 2; then compound 3.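

On the shared core, the aromatic carbon para to a large group does not need a carboxylic acid for a low number in this assay: 2-carbamoylcyclopropyl in place of 2-carboxypropyl gives a 79-fold lower number from compound 3 to compound 4 (1.90 log units; beyond the scatter). Compound 1, compound 2 and compound 3 all carry the acid, so they could not show this. The steps from compound 1 cannot be read, as compound 1 gives only a limit: the limit of < 10000 nM in this assay, at which 1 of the 4 values shown sits.

The three-membered ring and the carbamoyl group enter together, and a 2-carboxycyclopropyl or a 2-carbamoylpropyl group would separate their shares of the step. From the compounds shown here alone, the weight of the two defined stereocentres also stays open, and the opposite cyclopropyl stereoisomer would address it.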